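This account rests on a few compounds, and the source may have more. Where it says the series, first, only, none or still open, it means among the compounds named here.

Working notes on the series in an ADME assay on RAW264.7 cells (Mus musculus) for cytotoxicity, read by MTT assay, with a stated time of 24 h; a lower number here means that less compound is tolerated, a higher number that more compound is tolerated. Compound 1 `C/C=C/CCC(=O)O[C@H]1C=CC2=CC(=O)/C(=C(\C)C(=O)O)C[C@]2(C)[C@H]1C` gives > 50000 nM, which is a limit of the assay rather than a number. Compound 2 `C=C(CO)[C@@H]1C[C@@]2(C)C(=C[C@H](O)C[C@@H]2C)C[C@H]1O` gives > 50000 nM, also a limit. Compound 3 `C=C(C)[C@@H]1C[C@@]2(C)C(=C[C@H](O)C[C@@H]2C)C[C@H]1OC(C)=O` gives > 50000 nM, once more a limit, so for compound 3 only a limit is known. Within the data shown here, all three measured values sit at the limit of > 50000 nM in this assay, at which 3 of the 3 values shown sit, and no step between measured compounds can be read from them. Compound 4 `C=C(C)[C@@H]1C[C@@]2(C)C(=C[C@H](O)C[C@@H]2C)C[C@H]1O` differs from compound 3 by hydrogen in place of acetyl on an oxygen on a saturated carbon. Compound 2 also carries a free hydroxy and reaches the limit. In this assay the step that the limit leaves unreadable from compound 3 to compound 4 is expected to be none beyond the scatter. Compound 4 is expected at 60000 nM, within 30000 nM to 120000 nM, and most likely reported again as a limit.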

Compound 4, half-maximal cytotoxic concentration: > 50000 nM
Compound 4 was reported as a limit (the forecaster's own chance of this, stated with the estimate: 85%); the middle value does not contradict the limit.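

Compound 4 gives > 50000 nM, again a limit. Neither compound 2 nor compound 3 yields a readable step to compound 4, since every value sits at the same limit: the limit of > 50000 nM in this assay, at which 4 of the 4 values shown sit.

The compounds shown leave open at what concentration any of them would reach a half-maximal cytotoxic effect in this assay.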